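A few compounds are considered here, and "the series" means these few. Any claim that something is new, unique, unknown or untested is made for them only; others in the source may bear on it.

Compound 3, whose structure is `Cc1c(Cc2ccc(-c3ccccc3)cc2)c(=O)oc2cc(OCC(O)CN3CCC(C(N)=O)CC3)ccc12`, is the reference point here. In an ADME assay on A549 cells (Homo sapiens) for cytotoxicity, read by CellTiter-Glo (a higher number here means that more compound is tolerated, a lower number that less compound is tolerated), compound 3 gives only a limit, > 100000 nM, which is a boundary of the measurement rather than a number; of the three measured compounds it is the one sitting at the limit of > 100000 nM in this assay, at which 1 of the 3 values shown sits. Its two relatives differ from it in one place on the same aromatic carbon. Compound 1, `Cc1c(Cc2ccc(Cl)cc2)c(=O)oc2cc(OCC(O)CN3CCC(C(N)=O)CC3)ccc12`, carries chloro there and gives 40000 nM in this assay. Compound 2, `Cc1c(Cc2ccc(C(F)(F)F)cc2)c(=O)oc2cc(OCC(O)CN3CCC(C(N)=O)CC3)ccc12`, carries trifluoromethyl there and gives 89300 nM in this assay. The step of a 2.2-fold higher number from compound 1 to compound 2 (0.35 log units; beyond the scatter) and the step of an at least 2.5-fold higher number from compound 1 to compound 3 (0.39 log units; beyond the scatter) both run upward, while the step of an at least 1.1-fold higher number from compound 2 to compound 3 (0.04 log units; that floor lies within the scatter) has a floor that lies within the scatter.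

Compound 4, `Cc1c(Cc2ccc(-c3ccc(C=O)c(F)c3)cc2)c(=O)oc2cc(OCC(O)CN3CCC(C(N)=O)CC3)ccc12`, is not yet measured. Its change from compound 3 is 3-fluoro-4-formylphenyl in place of phenyl on an aromatic carbon. Among the compounds with values here, none of the measured steps swaps a group on the outer ring, so the bearing of the measured steps on it is indirect: they show that enlarging the group on that aromatic carbon has so far raised the number or left it at the limit. The step that the limit leaves unreadable from compound 3 to compound 4 is therefore expected to stay within the scatter. For compound 4 the estimated value in this assay is 110000 nM, with a range from 50000 nM to 250000 nM, and a limit rather than a number remains likely.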

Compound 4, half-maximal cytotoxic concentration: 62400 nM
Compound 4: the middle estimate sits 1.8-fold (0.25 log units) above what was measured; the measured number falls inside the stated range.
By their numbers in this assay, from the lowest: compounds 1, 4 and 2 (each within the scatter of the next, the first and the last beyond it). At a limit, above all of these: compound 3.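

Compound 3 gives a limit in this assay, not a number: the limit of > 100000 nM in this assay, at which 1 of the 4 values shown sits. Replacing its phenyl with 3-fluoro-4-formylphenyl gives an at least 1.6-fold lower number from compound 3 to compound 4 (0.20 log units; that floor lies within the scatter), so an aromatic ring at this position does not by itself keep the value at the limit, although this floor does not establish a real drop. Compared with the earlier groups on the same aromatic carbon, the new group gives a 1.4-fold lower number from compound 2 to compound 4 (0.16 log units; within the scatter) and a 1.6-fold higher number from compound 1 to compound 4 (0.19 log units; within the scatter), so the number for compound 4 cannot be separated from either, even though the step between those two earlier compounds lies beyond the scatter.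

Among the compounds shown, the fluoro and formyl groups appear only together on the outer ring, which leaves open whether either one alone would stay at the limit or give a measured number like that of compound 4. From the compounds shown here alone, it also remains open how an amine or a carboxylic acid at the same place on that outer ring would read in this assay.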